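Swapping Isopropoxy for Cyano: Expected Cytotoxicity Shift

The source may hold more compounds than are shown below. What is called first, only, known or untested is meant among the compounds shown, and "the series" means these compounds.

Of the compounds shown here, three have been measured in an ADME assay on L6 cells (Rattus norvegicus) for cytotoxicity, read by resazurin assay, with a stated time of 72 h; a higher number here means a weaker inhibitor, a lower number a stronger inhibitor. Compound 1 `CC(C)Oc1cccc(C(O)(c2ccc(Cl)cc2)c2cccnc2)c1` gives 67600 nM in this assay. Compound 2 `N#Cc1cccc(C(O)(c2ccc(Cl)cc2)c2cccnc2)c1` reaches only a limit of this assay, > 100000 nM. Compound 3 `CC(C)Oc1ccc(C(O)(c2ccc(Cl)cc2)c2cccnc2)c(F)c1` gives 58200 nM in this assay, a value within the scatter of compound 1. The difference between the cores of compound 1 and compound 3 is not broken down here.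

Within the data shown here, the one measured step, an at least 1.4-fold higher number from compound 1 to compound 2 (0.17 log units; that floor lies within the scatter), belongs to the change (cyano in place of isopropoxy on an aromatic carbon). Its floor rests on (the limit of > 100000 nM in this assay, at which 1 of the 3 values shown sits), so the true size of the step is not known.

Compound 4 `N#Cc1ccc(C(O)(c2ccc(Cl)cc2)c2cccnc2)c(F)c1` has not yet been measured. It differs from compound 3 by cyano in place of isopropoxy on an aromatic carbon. This is the same kind of change as from compound 1 to compound 2, though here the place is meta to a fluoro group and para to a large group, whereas before it was meta to a large group.

Because compound 2 sits at the limit > 100000 nM, compound 4 is expected to land near that same limit, giving an estimated step of a 1.7-fold higher number from compound 3 to compound 4 (0.24 log units; within the scatter). The estimate for compound 4 is 100000 nM, between 50000 nM and 200000 nM.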

Compound 4, half-maximal inhibitory concentration: > 100000 nM
Compound 4: no number, only a limit; the forecaster's own chance of this, stated with the estimate: 60%; the middle value lies on the limit itself.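

In this assay compound 4 gives no number, only a limit, > 100000 nM. Cyano in place of isopropoxy on an aromatic carbon gives an at least 1.7-fold higher number from compound 3 to compound 4 (0.23 log units; that floor lies within the scatter), so the change points the same way on the second core as on the first, though only as far as a floor within the scatter can show, and the two steps cannot be told apart: the same change on two cores in this assay, an at least 1.4-fold higher number (0.17 log units; that floor lies within the scatter) from compound 1 to compound 2 and an at least 1.7-fold higher number (0.23 log units; that floor lies within the scatter) from compound 3 to compound 4; the limit leaves it open whether they differ. On these data alone, the true size of either step remains unknown, and so does any real difference between the cores, since the cyano compounds give no numbers: the limit of > 100000 nM in this assay, at which 2 of the 4 values shown sit.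

The compounds shown leave open whether a different group in place of isopropoxy, such as an amine, a carboxylic acid or a longer alkoxy chain, would carry over from one core to the other in the same way. They also leave open whether any such group would give a number in this assay on both cores, which would allow the two steps to be compared directly.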